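Methyl on the phenolic oxygen: a small change in a urea series

A few compounds are considered here, and "the series" means these few. Any claim that something is new, unique, unknown or untested is made for them only; others in the source may bear on it.

Compound 1 `O=C(Nc1cccc(-n2cc(-c3ccncc3)c(-c3cc(O)cc(Cl)c3)n2)c1)Nc1ccc(Cl)c(Cl)c1`: 100%
Compound 2 `COc1cc(Cl)cc(-c2nn(-c3cccc(NC(=O)Nc4cc(C(F)(F)F)cc(C(F)(F)F)c4)c3)cc2-c2ccncc2)c1`: 97%

In a functional assay on CAKI-1 cells (Homo sapiens) for inhibition, read by sulforhodamine B assay, with a stated time of 48 h, tested at 0.01 uM (a lower number here means a stronger effect, a higher number a weaker effect of the compound at the concentration tested), compound 1 gives 100%, and compound 2 gives 97%; the gap between them is within the usual scatter, so the two cannot be told apart on these numbers. Compound 3 `COc1cc(Cl)cc(-c2nn(-c3cccc(NC(=O)Nc4ccc(Cl)c(Cl)c4)c3)cc2-c2ccncc2)c1` is not yet measured. It differs from compound 1 by methyl in place of hydrogen on an oxygen on an aromatic ring, hydroxy to methoxy. Going by the values given here, no step between measured compounds is recorded. Since compound 2, which also carries the methoxy, sits at 97%, the step from compound 1 to compound 3 is expected to be a number 2 percentage points lower from compound 1 to compound 3 (within the scatter), none beyond the scatter. Compound 3 is therefore estimated at 98%, between 86% and 106%.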

Compound 3, a percentage reported as activity, at one concentration (the size of the read-out at that concentration, not a potency): 96%
For compound 3 the middle estimate is 2 percentage points above the measured one, and the stated range covers the measured number.
By their numbers in this assay, from the lowest: compounds 3, 2 and 1 (each within the scatter of the next).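

In this assay the change from hydroxy to methoxy, now read alone with the rest of the structure unchanged, gives a number 4 percentage points lower from compound 1 to compound 3 (within the scatter) and so leaves the two compounds indistinguishable at this one concentration. Capping this oxygen with methyl thus has no readable effect on the read-out here. Nothing at hand explains this outcome.

From the compounds shown here alone, whether an ethoxy group on this oxygen, or an amine in place of the hydroxy, would shift the read-out remains open. So does whether compound 1 and compound 3 would separate at other concentrations.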